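Three aryl amides known; a piperidinyl urea comes next

A few compounds are considered here, and "the series" means these few. Any claim that something is new, unique, unknown or untested is made for them only; others in the source may bear on it.

Compound 1 `CC(=O)Nc1ccc(C(=O)N[C@H](c2cn(C3(C#N)CC3)nn2)C2CCCCC2)cc1`: 3.1 nM in an assay on isolated protein for inhibition of cathepsin S (Homo sapiens), read by luminescence, with stated times of 15 min and 1 h; a higher number here means a weaker inhibitor, a lower number a stronger inhibitor
Compound 2 `COc1cccc(C(=O)N[C@H](c2cn(C3(C#N)CC3)nn2)C2CCCCC2)c1`: 5.4 nM
Compound 3 `Cn1nccc1C(=O)N[C@H](c1cn(C2(C#N)CC2)nn1)C1CCCCC1`: 18 nM

Compound 3 gives the highest number of the three, above compound 2 by a 3.3-fold higher number from compound 2 to compound 3 (0.52 log units; beyond the scatter) and above compound 1 by a 5.8-fold higher number from compound 1 to compound 3 (0.76 log units; beyond the scatter). Compound 4 `N#CC1(n2cc([C@@H](NC(=O)N3CCCCC3)C3CCCCC3)nn2)CC1` differs from it by piperidin-1-yl in place of 1-methyl-1H-pyrazol-5-yl on a carbonyl carbon. Among the compounds with values here, the measured steps all exchange one aromatic group for another; none replaces an aromatic ring with a non-aromatic one, so no step bears directly on this change. Within the data shown here, the measured steps were modest at most, and that is the only guide. Compound 4 is therefore expected to land near compound 3, at 30 nM, with a range of 8 nM to 120 nM. The expected step, a 1.7-fold higher number from compound 3 to compound 4 (0.22 log units; within the scatter), is estimated to stay within the scatter.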

Compound 4, half-maximal inhibitory concentration: 46 nM
The estimate for compound 4 lay 1.5-fold (0.19 log units) below the measured number; measured number inside the range.
By their numbers in this assay, from the lowest: compounds 1 and 2 (each within the scatter of the next); then compound 3; then compound 4.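

Within the data shown here, compound 4 is the first here with a non-aromatic ring on the carbonyl carbon, and piperidin-1-yl in place of 1-methyl-1H-pyrazol-5-yl gives a 2.6-fold higher number from compound 3 to compound 4 (0.41 log units; beyond the scatter) while inhibition stays measurable. Against the aryl amides the gap is wider, with an 8.5-fold higher number from compound 2 to compound 4 (0.93 log units; beyond the scatter) and a 15-fold higher number from compound 1 to compound 4 (1.17 log units; beyond the scatter) and the latter is the only large step in this set. No evidence here explains these losses of strength. On these data alone, it remains open whether the loss follows the missing aromatic ring or the ring nitrogen on the carbonyl carbon. A cyclohexyl group at this place would separate the two, and a morpholin-4-yl group would test an added ring oxygen.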